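The source may hold more compounds than are shown below. What is called first, only, known or untested is meant among the compounds shown, and "the series" means these compounds.

For the measured compounds named here, compound 2 `O=C(CN1CCC(c2cccc[n+]2[O-])CC1)Nc1cccc(F)c1` gives 160 nM in a functional assay on HEK293 cells for agonist activity at D(4) dopamine receptor (Homo sapiens), read by FLIPR (on this read-out higher numbers stand for an effect only at larger amounts of compound and lower numbers for an effect already at smaller amounts), which places it second highest of the three numbers measured so far. Its nearest neighbour is compound 3 `CC(C)Oc1cccc(NC(=O)CN2CCC(c3cccc[n+]3[O-])CC2)c1`, which in this assay gives 555 nM; furthest from it is compound 1 `Cc1cccc(C(=O)NCN2CCC(c3nccs3)CC2)c1`, which in this assay gives 9.8 nM. The unmeasured compound 4 `O=C(CN1CCC(c2cccc[n+]2[O-])CC1)Nc1cc(Cl)cc(Cl)c1` differs from compound 2 in one place: 3,5-dichlorophenyl in place of 3-fluorophenyl on an amide-type nitrogen. Going by the values given here, the only measured step that bears on this change is the one that also alters the 3-fluorophenyl of compound 2, where a 3.5-fold higher number from compound 2 to compound 3 (0.54 log units; beyond the scatter) moved the number modestly upward. Among the compounds with values here, that step exchanges fluoro for isopropoxy rather than for a 3,5-dichlorophenyl, so it is only a loose guide, and no measured step shows a second substituent on that ring. The change to compound 4 is therefore expected to shift this assay upward by a small amount, a 1.6-fold higher number from compound 2 to compound 4 (0.19 log units; within the scatter), although a result within the scatter cannot be excluded. Compound 4 is estimated at 250 nM, with a range from 80 nM to 800 nM.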

Compound 4, half-maximal effective concentration: 160 nM
Compound 4: middle estimate off by 1.6-fold (0.19 log units), on the high side, within the range that was stated.
By their numbers in this assay, from the lowest: compound 1; then compounds 2 and 4 (each within the scatter of the next); then compound 3.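

In this assay, 3,5-dichlorophenyl in place of 3-fluorophenyl on an amide-type nitrogen gives no change at the digits printed from compound 2 to compound 4 (within the scatter). For the compounds shown here, this position therefore tolerates a ring carrying two chlorine atoms and no fluorine without a shift beyond the scatter, whereas the only earlier change there, with isopropoxy in place of fluoro, gave a 3.5-fold higher number from compound 2 to compound 3 (0.54 log units; beyond the scatter). Nothing measured here explains why these two changes at the same ring differ.

The compounds shown leave open whether a single chloro, a methoxy or a nitrile on that ring would also stay within the scatter of compound 2. They also leave open how an amine or a carboxylic acid on that ring would read out, and whether a larger alkoxy group would move the number further than isopropoxy did.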